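A few compounds are considered here, and "the series" means these few. Any claim that something is new, unique, unknown or untested is made for them only; others in the source may bear on it.

Among the compounds with values here, compound 1, `CCCC(=O)c1ccc(OCCCCOc2ccc(F)c(C(=O)O)c2)c(C)c1O`, is the better of the two compounds measured so far in an assay on HEK293 cells for positive allosteric modulation of metabotropic glutamate receptor 3 (Rattus norvegicus), read by thallium flux, with a stated time of 2.5 min; a higher number here means a larger maximal response, a lower number a smaller maximal response: in this assay compound 1 reaches 56.9%. Within the data shown here, its nearest neighbour, compound 2, `COc1cc(C(=O)O)ccc1OCCCCOc1ccc(C(C)=O)c(O)c1C`, reaches only 26.3% in this assay, and the gap between the two values lies beyond the usual scatter of the measurement; no single structural step links these two compounds, so the pair says only that much.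

Compound 3, `Cc1c(OCCCCOc2ccc(F)c(C(=O)O)c2)ccc(C(=O)CC2CCCC2)c1O`, is not yet measured. It differs from compound 1 in one place: cyclopentyl in place of ethyl on a saturated chain carbon bound to a carbonyl carbon. The cyclopentyl thus enters where the ethyl of compound 1 left, on the saturated chain carbon bound to the carbonyl carbon, and nothing else of the shared core is touched.

Among the measured compounds shown here, no measured pair in this assay shows what such an exchange does, so the expectation rests on compound 1 alone. The step from compound 1 to compound 3 is expected to be small, a number 1.9 percentage points lower from compound 1 to compound 3 (within the scatter), with no clear direction beyond the scatter. Compound 3 is therefore estimated at 55% in this assay, within a range from 35% to 75%.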

Compound 3, largest response reached (reported as percent of maximum), in percent of the reference or control that the assay uses: 98.4%
Compound 3: middle estimate off by 43.4 percentage points, on the low side; the whole stated range lies below it.
By their numbers in this assay, from the lowest: compound 2; then compound 1; then compound 3.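

Within the data shown here, the exchange of ethyl for cyclopentyl, on a saturated chain carbon bound to a carbonyl carbon, is the first single-place change that can be read in this assay, and it gives a number 41.5 percentage points higher from compound 1 to compound 3 (beyond the scatter) as a large step. It shows that the maximal response is sensitive to the group at this position, even though the rest of the shared core stays the same and neither group carries a hydrogen-bond donor, a hydrogen-bond acceptor or a net charge. Nothing shown bears on why this change has so large an effect.

With one exchange at this position, the compounds shown cannot separate the presence of the ring from the larger number of carbon atoms, and a longer open chain such as pentyl, or another ring such as cyclohexyl or phenyl, could settle that point. As far as these compounds go, compound 2 differs from both other compounds in more than one place, so it remains open whether cyclopentyl would bring a similar step on the core of compound 2.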